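Changing the group on a carbonyl-linked oxygen

The compounds below may be only part of what the source reports. "The series", "measured", "known", "first", "only" and "open" are said of these compounds alone.

Two measured compounds share one core that carries a long branched chain. Compound 1 `CC(C)=CCC/C(C)=C/CC/C(C)=C/CSc1ccccc1C(=O)N(C)C` has a dimethylamino on its carbonyl carbon, and in a functional assay on U-87MG ATCC cells (Homo sapiens) for cytotoxicity, with a stated time of 7 days (a higher number here means a weaker inhibitor, a lower number a stronger inhibitor), compound 1 gives 20000 nM. Compound 2 `COCOC(=O)c1ccccc1SC/C=C(\C)CC/C=C(\C)CCC=C(C)C` carries a methoxymethoxy on that carbonyl carbon instead, and in this assay compound 2 gives 10000 nM. That single exchange produced a 2.0-fold lower number from compound 1 to compound 2 (0.30 log units; within the scatter), so the two numbers cannot be told apart; compound 2 shows the lower of the two values, but not a separable one.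

Compound 3 `CC(C)=CCC/C(C)=C/CC/C(C)=C/CSc1ccccc1C(=O)OC(C)C` takes the next step: isopropyl in place of methoxymethyl on an oxygen next to a carbonyl group. Within the data shown here, only one measured step bears on this region, the exchange at the carbonyl carbon, a 2.0-fold lower number from compound 1 to compound 2 (0.30 log units; within the scatter), which stayed within the scatter. Since replacing the whole group on the carbonyl carbon hardly moved the number, a change one bond further out, inside the group on the oxygen, is expected to move it little as well, and the expected step is no change at the digits printed from compound 2 to compound 3 (within the scatter). For compound 3 the estimated value is 10000 nM, expected to fall between 4000 nM and 25000 nM.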

Compound 3, half-maximal inhibitory concentration: 52000 nM
The estimate for compound 3 lay 5.2-fold (0.72 log units) below the measured number; the measured number lies above the stated range.
By their numbers in this assay, from the lowest: compounds 2 and 1 (each within the scatter of the next); then compound 3.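

In this assay the group on the oxygen next to the carbonyl group turns out to matter: isopropyl in place of methoxymethyl gives a 5.2-fold higher number from compound 2 to compound 3 (0.72 log units; beyond the scatter) and so separates two compounds, where the earlier exchange on the carbonyl carbon could not be told from scatter. The two groups have the same count of heavy atoms, and methoxymethyl holds an oxygen where isopropyl holds only carbon, so a swap that keeps this count can still shift the number to a weaker inhibitor. Isopropoxy in place of dimethylamino on the carbonyl carbon likewise gives a 2.6-fold higher number from compound 1 to compound 3 (0.41 log units; beyond the scatter) and sets compound 3 apart from both others, while compound 1 and compound 2 remain within the scatter of each other, and no measurement shown here gives a reason for this shift.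

Open, on these data alone, is how the number responds to other groups on this oxygen, such as a plain methyl, a longer straight chain or a benzyl. Also open, as far as these compounds go, is whether a free carboxylic acid or a primary amide on the same carbonyl carbon would stay with compound 1 and compound 2 or fall nearer compound 3.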